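The compounds below may be only part of what the source reports. "The series", "measured", "known", "first", "only" and "open" are said of these compounds alone.

Measured compounds in a functional assay on HeLa cells (Homo sapiens) for antiproliferative activity, read by sulforhodamine B assay, with a stated time of 48 h; on this read-out higher numbers stand for weaker inhibition and lower numbers for stronger inhibition:
compound 1 `Cc1cc(NS(=O)(=O)c2ccc(N/C(S)=N\c3ccnc4cc(C(F)(F)F)ccc34)cc2)on1`: 60200 nM
compound 2 `O=S(=O)(Nc1nccs1)c1ccc(N/C(S)=N\c2ccnc3cc(C(F)(F)F)ccc23)cc1`: 95200 nM
compound 3 `O=S(=O)(Nc1ccccn1)c1ccc(N/C(S)=N\c2ccnc3cc(C(F)(F)F)ccc23)cc1`: 68800 nM

Compound 3 sits within the scatter of both other compounds: a 1.1-fold higher number from compound 1 to compound 3 (0.06 log units; within the scatter) and a 1.4-fold lower number from compound 2 to compound 3 (0.14 log units; within the scatter), and the whole set spans only a 1.6-fold higher number from compound 1 to compound 2 (0.20 log units; within the scatter). Compound 4 `Cc1ccnc(NS(=O)(=O)c2ccc(N/C(S)=N\c3ccnc4cc(C(F)(F)F)ccc34)cc2)n1` carries the change (4-methylpyrimidin-2-yl in place of pyridin-2-yl on a sulfonamide nitrogen). Every measured step exchanges one heteroaryl group on the same sulfonamide nitrogen, and none of them moved the number beyond the scatter, so for this further exchange no step beyond the scatter is expected in this assay, in no particular direction. Compound 4 is therefore expected to give 70000 nM in this assay, with a range of 35000 nM to 140000 nM. This estimate means a step of a 1.0-fold higher number from compound 3 to compound 4 (0.01 log units; within the scatter), expected to remain within the scatter.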

Compound 4, half-maximal inhibitory concentration: 31000 nM
Beside the measured number, compound 4's estimate is 2.3-fold (0.35 log units) above it, and the stated range ends above it.
By their numbers in this assay, from the lowest: compounds 4, 1, 3 and 2 (each within the scatter of the next, the first and the last beyond it).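

In this assay this sulfonamide nitrogen now shows steps beyond the scatter, which no earlier heteroaryl exchange gave: 4-methylpyrimidin-2-yl in place of pyridin-2-yl gives a 2.2-fold lower number from compound 3 to compound 4 (0.35 log units; beyond the scatter) and in place of 1,3-thiazol-2-yl gives a 3.1-fold lower number from compound 2 to compound 4 (0.49 log units; beyond the scatter) as a second modest step. In place of 3-methyl-1,2-oxazol-5-yl it gives only a 1.9-fold lower number from compound 1 to compound 4 (0.29 log units; within the scatter) and so does not separate from that compound.

Still open, as far as these compounds go, is whether the methyl or the second ring nitrogen carries these steps, which pyrimidin-2-yl without the methyl would help to separate. No measurement in hand gives a cause for them.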